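Pyrimidine anilines: dropping the methoxy from compound 2

The compounds below may be only part of what the source reports. "The series", "measured", "known", "first", "only" and "open" are said of these compounds alone.

Measured so far in a functional assay for inhibition, with Homo sapiens as the target; on this read-out lower numbers stand for stronger inhibition and higher numbers for weaker inhibition:
compound 1 `Cc1cc(-c2ccnc(Nc3ccc(N(C)C)cc3)n2)c(C)o1`, 4900 nM
compound 2 `COc1cccc(Nc2nccc(-c3cc(C)oc3C)n2)c1`, 5800 nM
compound 3 `COc1cccc(Nc2nccc(-c3ccsc3)n2)c1`, 1800 nM

Compound 2 has the highest of the three numbers; compound 1 sits within the scatter of it, while the step of a 3.2-fold lower number from compound 2 to compound 3 (0.51 log units; beyond the scatter) is the only one beyond the scatter. Compound 4 `Cc1cc(-c2ccnc(Nc3ccccc3)n2)c(C)o1` differs from compound 2 by hydrogen in place of methoxy on an aromatic carbon; the place is an aromatic carbon of a six-membered aromatic ring of carbon only, meta to a large group. Among the compounds with values here, no measured step touches this position: the step from compound 2 to compound 3 changes the other ring, so it does not bear on the methoxy. Without a precedent, no step beyond the scatter is expected in this assay ; the estimate for compound 4 is 6000 nM (range 2500 nM to 14000 nM), a step of a 1.0-fold higher number from compound 2 to compound 4 (0.01 log units; within the scatter).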

Compound 4, half-maximal inhibitory concentration: 2000 nM
Compound 4: the middle estimate sits 3.0-fold (0.48 log units) above what was measured; measured number outside the range, below it.
By their numbers in this assay, from the lowest: compounds 3 and 4 (each within the scatter of the next); then compounds 1 and 2 (each within the scatter of the next).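

In this assay, within the data shown here, the methoxy at this place is not needed for activity: hydrogen in its place gives a 2.9-fold lower number from compound 2 to compound 4 (0.46 log units; beyond the scatter), beyond the scatter where no step had been expected. The same hydrogen in place of dimethylamino gives a 2.5-fold lower number from compound 1 to compound 4 (0.39 log units; beyond the scatter), so neither substituent on the aromatic ring improves on plain hydrogen with the 2,5-dimethylfuran-3-yl group in place. No evidence on hand accounts for these steps.

Going by these compounds, whether fluorine, chlorine, a hydroxyl or a carboxylic acid on this aromatic carbon would also compare poorly with hydrogen remains open. Also open, on these data alone, is whether hydrogen in place of methoxy gives a similar step alongside the thiophen-3-yl group of compound 3.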